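Acrylamide series: para substituent swap on the pendant phenyl

A few compounds are considered here, and "the series" means these few. Any claim that something is new, unique, unknown or untested is made for them only; others in the source may bear on it.

Measured so far:
compound 1 `C=CC(=O)N1C(=O)CC(c2ccc([N+](=O)[O-])cc2)Sc2ccccc21`: 34800 nM
compound 2 `C=CC(=O)N1C(=O)CC(c2ccccc2Cl)Sc2ccccc21`: 50400 nM
compound 3 `C=CC(=O)N1C(=O)CC(C)Sc2ccccc21`: 837000 nM

In a functional assay on Raji cells (Homo sapiens) for cytotoxicity, read by CCK-8 assay, with a stated time of 24 h (a higher number here means a weaker inhibitor, a lower number a stronger inhibitor), compound 1 gives 34800 nM, the lowest of the three numbers; compound 2 lies within the scatter of it, compound 3 far beyond it. Going by the values given here, the one step between single-change neighbours, a 17-fold higher number from compound 2 to compound 3 (1.22 log units; beyond the scatter), concerns methyl in place of 2-chlorophenyl on a saturated ring carbon, not the aromatic substituent, so it does not bear directly on compound 4 `C=CC(=O)N1C(=O)CC(c2ccc(Br)cc2)Sc2ccccc21`. Compound 4 differs from compound 1 by bromo in place of nitro on an aromatic carbon. Among the compounds with values here, the only guide is that compound 1 and compound 2, which differ in their aryl substitution, sit within the scatter of each other, so no step beyond the scatter is expected. Compound 4 is therefore estimated at 35000 nM (range 12000 nM to 100000 nM), a step of a 1.0-fold higher number from compound 1 to compound 4 (0.00 log units; within the scatter) expected.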

Compound 4, half-maximal inhibitory concentration: 51300 nM
Compound 4: the middle estimate sits 1.5-fold (0.17 log units) below what was measured; measured number inside the range.
By their numbers in this assay, from the lowest: compounds 1, 2 and 4 (each within the scatter of the next); then compound 3.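

In this assay, bromo in place of nitro on an aromatic carbon, para to a large group, stays within the scatter (a 1.5-fold higher number from compound 1 to compound 4 (0.17 log units; within the scatter)), and compound 4 also matches compound 2 (a 1.0-fold higher number from compound 2 to compound 4 (0.01 log units; within the scatter)), so three aryl substitution patterns now cannot be told apart. The methyl compound stands apart from a second aryl neighbour (a 16-fold lower number from compound 3 to compound 4 (1.21 log units; beyond the scatter)), consistent with the earlier step (a 17-fold higher number from compound 2 to compound 3 (1.22 log units; beyond the scatter)). No measurement available here explains these results.

As far as these compounds go, an amine or a carboxylic acid on the pendant phenyl remains open, as does a longer chain in place of the methyl.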